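This account rests on a few compounds, and the source may have more. Where it says the series, first, only, none or still open, it means among the compounds named here.

Measured in a functional assay on B16 cells (Mus musculus) for cytotoxicity; a lower number here means a stronger inhibitor, a higher number a weaker inhibitor:
compound 1 `COc1ccc(/C=C\c2cc(OC)c(OC)c(OC)c2)cc1B(O)O`: 6.3 nM
compound 2 `COc1cc(/C=C\c2cccc(B(O)O)c2)cc(OC)c1OC`: 490 nM
compound 3 `COc1cc(/C=C\c2ccc(OC)c(B(O)O)c2)cc(OC)c1`: 19 nM

Compound 1 has the lowest number of the three, which makes it the strongest inhibitor in this small set. Compound 4 `COc1ccc(/C=C\c2cc(OC)c(OC)c(OC)c2)cc1C(=O)O` keeps the core of compound 1 and changes a single group: a group of 3 heavy atoms (1 carbon, 2 oxygen; no ring) in place of a group of 3 heavy atoms (1 boron, 2 oxygen; no ring), on an aromatic carbon. The incoming group is a carboxy, on an aromatic carbon, ortho to a methoxy group.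

Neither measured step touches that group. Each one puts hydrogen in place of methoxy, so they offer only a rough scale for how far one change can move this assay. One step is large, a 78-fold higher number from compound 1 to compound 2 (1.89 log units; beyond the scatter), and the other is modest, a 3.0-fold higher number from compound 1 to compound 3 (0.48 log units; beyond the scatter). All three measured compounds carry the group that compound 4 loses, and none carries a carboxy, so the data give no direct reading of this swap.

Compound 1 already sits lowest at 6.3 nM, so a higher number is the likelier direction, and a large step seems more plausible than a small one. The expected step is a 320-fold higher number from compound 1 to compound 4 (2.50 log units; beyond the scatter). The estimate for compound 4 is 2000 nM, with an expected range of 150 nM to 30000 nM.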

Compound 4, half-maximal inhibitory concentration: 160000 nM
For compound 4 the middle estimate is 80-fold (1.90 log units) below the measured one; measured number above the stated range.
By their numbers in this assay, from the lowest: compound 1; then compound 3; then compound 2; then compound 4.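

Putting a carboxy in place of the boron-bearing group, on the aromatic carbon ortho to a methoxy group, gives a 25000-fold higher number from compound 1 to compound 4 (4.40 log units; beyond the scatter) in this assay, a larger step than either loss of a methoxy, a 78-fold higher number from compound 1 to compound 2 (1.89 log units; beyond the scatter) and a 3.0-fold higher number from compound 1 to compound 3 (0.48 log units; beyond the scatter). Within the data shown here, all the earlier compounds kept the boron-bearing group, so only this result shows that the number depends so heavily on what sits at this carbon, even though the incoming and outgoing groups have the same count of heavy atoms and neither has a ring. Among these compounds, no measurement here bears on why this swap moves the number so far.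

One swap cannot show whether the boron-bearing group is unusually favourable or the carboxy unusually poor, and a plain hydrogen, an amine or a carboxamide at the same carbon would help separate those two readings. As far as these compounds go, it also remains open whether a carboxy would move the number as far when placed on the structures of compound 2 or compound 3, which each lack one of the methoxy groups of compound 1.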